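The source may report more compounds than this note shows. Statements on the series, on what has been measured and on what is new or still open speak of the compounds shown alone.

In a functional assay on A 172 cells (Homo sapiens) for cytotoxicity, read by colorimetric assay and MTT assay (on this read-out higher numbers stand for weaker inhibition and lower numbers for stronger inhibition), compound 1 `COc1ccc(-c2cc3cccc(OC)c3nc2O)cc1` gives 10000 nM. Compound 2 `COc1ccc(-c2cc3c(OC)cc(OC)cc3n(CCCC#N)c2=O)cc1` gives 10000 nM, which is level with compound 1 within the usual scatter. Compound 3 `COC(=O)CCn1c(=O)c(-c2ccc(OC)cc2)cc2c(OC)cc(OC)cc21` shares its core with compound 2 and differs in one place: methoxycarbonyl in place of cyanomethyl on a saturated chain carbon, two bonds along the chain from an aromatic nitrogen. In words, methoxycarbonyl stands in place of cyanomethyl on a saturated chain carbon, two bonds along the chain from an aromatic nitrogen. Among the measured compounds shown here, no measured pair shows what this swap does, so no step beyond the scatter is expected in this assay. For compound 3, the estimated value is 10000 nM, with an expected range of 3500 nM to 30000 nM.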

Compound 3, half-maximal inhibitory concentration: 10000 nM
Compound 3: middle estimate and measured number agree at the digits printed; low and high end bracket the measured number.
By their numbers in this assay, from the lowest: compounds 1, 2 and 3 (each within the scatter of the next).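

In this assay, putting methoxycarbonyl in place of cyanomethyl on a saturated chain carbon, two bonds along the chain from an aromatic nitrogen, gives no change at the digits printed from compound 2 to compound 3 (within the scatter). Among the compounds shown here, this is the first direct reading at this position, and on this read-out the two groups cannot be told apart. No other information here bears on this result. Going by these compounds, whether a carboxylic acid or an amine in this place would shift the number remains open. So does the effect of a longer chain between the aromatic nitrogen and the end group.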